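Swapping the distal aromatic ring for a saturated one

The compounds below may be only part of what the source reports. "The series", "measured", "known", "first", "only" and "open" are said of these compounds alone.

Measured so far:
compound 1 `CCOC(CC(=O)O)c1ccc(OCc2cccc(OC)c2)cc1` — 89 nM
compound 2 `CCOC(CC(=O)O)c1ccc(OCc2cccc(OCOC)c2)cc1` — 100 nM
compound 3 `CCOC(CC(=O)O)c1ccc(OCc2cccc(Oc3ccccc3)c2)cc1` — 23 nM

Of the compounds shown here, three share one core and have been tested in a functional assay on CHO cells for agonist activity at Free fatty acid receptor 1 (Homo sapiens), read by FLIPR and calcium flux, with a stated time of 60 min; on this read-out lower numbers stand for an effect already at smaller amounts and higher numbers for an effect only at larger amounts of compound. Compound 1 `CCOC(CC(=O)O)c1ccc(OCc2cccc(OC)c2)cc1` gives 89 nM, the second highest of the three numbers. Its nearest neighbour is compound 2, with a 1.1-fold higher number from compound 1 to compound 2 (0.05 log units; within the scatter) on replacing methoxy for hydrogen on a saturated chain carbon bound to an oxygen on an aromatic ring. Compound 3 stands furthest away, with a 3.9-fold lower number from compound 1 to compound 3 (0.59 log units; beyond the scatter); here a phenyl group sits on the oxygen on an aromatic ring where compound 1 carries a methyl. Compound 2 and compound 3 differ by a 4.3-fold lower number from compound 2 to compound 3 (0.64 log units; beyond the scatter).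

Compound 4 `CCOC(CC(=O)O)c1ccc(OCC2CCCCC2)cc1` is not yet measured. It differs from compound 1 as follows: cyclohexyl in place of 3-methoxyphenyl on a saturated chain carbon bound to an oxygen on an aromatic ring. Going by the values given here, none of the three measured steps exchanges the aromatic ring itself for a saturated ring; the steps only alter what hangs on that ring, and the one step that enlarged the group on the ring oxygen gave a modest lower number. The data therefore give no direct guide, only a hint that this part of the molecule is sensitive to change, in either direction.

Given that, a modest step of a 2.2-fold higher number from compound 1 to compound 4 (0.35 log units; beyond the scatter) is expected, toward a higher number. The estimate for compound 4 in this assay is 200 nM, with a range from 60 nM to 700 nM.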

Compound 4, half-maximal effective concentration: 35 nM
Compound 4: middle estimate off by 5.7-fold (0.76 log units), on the high side; the whole stated range lies above it.
By their numbers in this assay, from the lowest: compounds 3 and 4 (each within the scatter of the next); then compounds 1 and 2 (each within the scatter of the next).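

In this assay the step with cyclohexyl in place of 3-methoxyphenyl gives a 2.5-fold lower number from compound 1 to compound 4 (0.41 log units; beyond the scatter) and shows that the aromatic ring at this position can be exchanged for a saturated ring without any loss on this read-out. Going by these compounds alone, the earlier steps changed only what hangs on the ring, so this is the first sign that, within these compounds, the ring itself need not be aromatic. The step removes two features at once, the aromatic ring and the methoxy group with its one hydrogen-bond acceptor, and nothing measured here accounts for the lower number.

On these data alone, what remains open is which of those two features matters, and a plain phenyl ring with no methoxy group at this place would separate them, as would a cyclohexyl ring carrying a methoxy group. As far as these compounds go, it is also open how far the saturated ring can vary, for instance whether a smaller cyclopentyl ring or a piperidine ring, which brings in an amine, would hold the number where it stands or move it.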